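A few compounds are considered here, and "the series" means these few. Any claim that something is new, unique, unknown or untested is made for them only; others in the source may bear on it.

Compound 1 `CC(C)CCSc1nc(C(F)(F)F)ccc1CNC(=O)C(C)c1ccc(NS(C)(=O)=O)c(F)c1`: 82 nM in an assay on CHO-K1 cells for antagonist activity at transient receptor potential cation channel subfamily V member 1 (Homo sapiens), read by FLIPR; on this read-out lower numbers stand for stronger inhibition and higher numbers for weaker inhibition
Compound 2 `COC(=O)CCSc1nc(C(F)(F)F)ccc1CNC(=O)C(C)c1ccc(NS(C)(=O)=O)c(F)c1`: 1100 nM in this assay

Compound 2 stands highest of these two numbers; the step of a 13-fold higher number from compound 1 to compound 2 (1.13 log units; beyond the scatter) lies well beyond the usual scatter of repeated measurements. Compound 3 `CC(C(=O)NCc1ccc(C(F)(F)F)nc1SCc1ccc(Cl)cc1)c1ccc(NS(C)(=O)=O)c(F)c1` is the next compound to be tested in this assay. It differs from compound 2 in a single place: 4-chlorophenyl in place of (methoxycarbonyl)methyl on a saturated chain carbon bound to a sulfur. Going by the values given here, the one measured step that touches this part of the molecule is a 13-fold higher number from compound 1 to compound 2 (1.13 log units; beyond the scatter), and it was large, so the group carried on the chain beyond the sulfur clearly has a strong say in the number. Neither measured compound carries the 4-chlorophenyl that enters here, so the size of the coming step can only be judged loosely. Compound 2 holds the highest number seen so far, and exchanging the group on its chain is expected to lower the number rather than raise it. The expected step is a 9.2-fold lower number from compound 2 to compound 3 (0.96 log units; beyond the scatter). For compound 3 the estimate in this assay is 120 nM, with a range from 30 nM to 500 nM.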

Compound 3, half-maximal inhibitory concentration: 674 nM
Compound 3: the middle estimate sits 5.6-fold (0.75 log units) below what was measured, outside the stated range (above it).
By their numbers in this assay, from the lowest: compound 1; then compounds 3 and 2 (each within the scatter of the next).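

In this assay, 4-chlorophenyl in place of (methoxycarbonyl)methyl gives a 1.6-fold lower number from compound 2 to compound 3 (0.21 log units; within the scatter). Two quite different groups therefore cannot be told apart here: one brings a double bond and hydrogen-bond acceptors, and the other brings an aromatic ring of carbon only and a chlorine. Setting the same 4-chlorophenyl against the isobutyl gives an 8.2-fold higher number from compound 1 to compound 3 (0.91 log units; beyond the scatter), so the aromatic ring does not bring the number down to that of compound 1, which now stands apart from both other compounds, and nothing shown here explains why the isobutyl end of the chain fares best.

The compounds shown leave open whether the low number of compound 1 belongs to isobutyl alone or to saturated carbon groups on this chain more widely, a question that a cyclohexyl group or a longer alkyl chain would address. They also leave open whether the chlorine matters to compound 3 and how the chain would respond to a plain phenyl, a carboxylic acid or an amine at its end.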